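The compounds below may be only part of what the source reports. "The series", "measured", "known", "first", "only" and "open" are said of these compounds alone.

Measured in a physicochemical assay for lipophilicity, using the shake flask method, at pH 7.4; a lower number here means a more polar compound, a higher number a more lipophilic compound:
compound 1 `Cc1ccccc1CNC(=O)c1nc(-c2ccc(F)cc2)n(CC[C@@H](O)C[C@@H](O)CC(=O)O)c1C1CC1`: 0.44
compound 2 `O=C(O)C[C@H](O)C[C@H](O)CCn1c(-c2ccc(F)cc2)nc(C(=O)NCc2ccc(F)cc2)c1C1CC1`: 0.17
compound 3 `COc1ccc(CNC(=O)c2nc(-c3ccc(F)cc3)n(CC[C@@H](O)C[C@@H](O)CC(=O)O)c2C2CC2)cc1`: 0.02

The position of compound 3 rests on two steps: a number 0.15 log units lower from compound 2 to compound 3 (within the scatter), and a number 0.42 log units lower from compound 1 to compound 3 (beyond the scatter). It therefore cannot be separated from compound 2, and only compound 1 stands clear of it.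

The next compound, compound 4 `COc1cccc(CNC(=O)c2nc(-c3ccc(F)cc3)n(CC[C@@H](O)C[C@@H](O)CC(=O)O)c2C2CC2)c1`, has 3-methoxyphenyl in place of 4-methoxyphenyl on a saturated chain carbon bound to an amide-type nitrogen. The two have the same atoms, joined differently.

All three measured steps change the group at this same place. The third of them reads a number 0.27 log units lower from compound 1 to compound 2 (within the scatter). Among the compounds with values here, each of these swaps one group for a different one, and none keeps a methoxy group while moving it, so the series holds no direct precedent for this change. Even so, the replacements measured at this place stay modest in this assay, and the change to compound 4 is the more conservative one. No shift beyond the scatter is expected, and the estimated step is a number 0.08 log units higher from compound 3 to compound 4 (within the scatter).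

For compound 4 the estimated value is 0.1, with an expected range from -0.25 to 0.45.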

Compound 4, distribution coefficient: 0.11
Compound 4: middle estimate off by 0.01 log units, on the low side; measured number inside the range.
By their numbers in this assay, from the lowest: compounds 3, 4, 2 and 1 (each within the scatter of the next, the first and the last beyond it).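

Moving the methoxy group gives the first reading at this position in which the group keeps its atoms and only the way they are joined changes: a number 0.09 log units higher from compound 3 to compound 4 (within the scatter) in this assay, so 3-methoxyphenyl and 4-methoxyphenyl cannot be told apart here. The 3-methoxyphenyl group also cannot be separated from 4-fluorophenyl, with a number 0.06 log units lower from compound 2 to compound 4 (within the scatter), yet it stands clear of 2-methylphenyl, with a number 0.33 log units lower from compound 1 to compound 4 (beyond the scatter), so both methoxy compounds now lie beyond the scatter from compound 1, while compound 2 does not, with a number 0.27 log units lower from compound 1 to compound 2 (within the scatter). No measurement is available that would explain these readings.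

Compound 1 differs from both methoxy compounds in the substituent and in how it is joined to the ring, so the compounds shown cannot assign the gap to either difference. As far as these compounds go, how an unsubstituted phenyl ring, or a phenyl ring bearing an amine or a carboxylic acid, would read at this place in this assay remains open, as does whether the small step between the two methoxy isomers holds for other substituents.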